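Heteroaryl amide variation at the chain terminus

This account rests on a few compounds, and the source may have more. Where it says the series, first, only, none or still open, it means among the compounds named here.

Two compounds of the series share a long-chain core carrying an amide whose carbonyl bears a five-membered heteroaryl ring. Compound 1 `CCCCCCCCCCCC[C@@H](O)[C@H]1CC[C@H]([C@H](O)CCCCCCCCCCNC(=O)c2cncs2)O1` carries a 1,3-thiazol-5-yl ring; in a functional assay on A549 cells (Homo sapiens) for inhibition, read by colorimetric assay and sulforhodamine B assay, with a stated time of 48 h (on this read-out lower numbers stand for stronger inhibition of growth and higher numbers for weaker inhibition of growth), compound 1 gives 34700 nM. Compound 2 `CCCCCCCCCCCC[C@@H](O)[C@H]1CC[C@H]([C@H](O)CCCCCCCCCCNC(=O)c2ccsc2)O1` carries a thiophen-3-yl ring in its place, and in this assay compound 2 gives 100000 nM. Within the data shown here, compound 2 thus stands at the higher of the two numbers, the only measured step being a 2.9-fold higher number from compound 1 to compound 2 (0.46 log units; beyond the scatter).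

The next compound, compound 3 `CCCCCCCCCCCC[C@@H](O)[C@H]1CC[C@H]([C@H](O)CCCCCCCCCCNC(=O)c2ccco2)O1`, changes the same position: furan-2-yl in place of thiophen-3-yl on a carbonyl carbon. Among the measured compounds shown here, the one measured step that bears on it is the heteroaryl swap from compound 1 to compound 2, which was modest in size, so a swap between two five-membered rings with one hetero atom is not expected to move the number far. Because compound 2 already gives 100000 nM, the expected step of a 1.4-fold lower number from compound 2 to compound 3 (0.15 log units; within the scatter) lies within or just beyond the scatter, with the direction uncertain. Compound 3 is therefore estimated at 70000 nM in this assay, with a range from 25000 nM to 200000 nM.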

Compound 3, concentration for 50% growth inhibition: 100000 nM
For compound 3 the middle estimate is 1.4-fold (0.15 log units) below the measured one; low and high end bracket the measured number.
By their numbers in this assay, from the lowest: compound 1; then compounds 2 and 3 (each within the scatter of the next).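

In this assay, furan-2-yl in place of thiophen-3-yl on a carbonyl carbon gives no change at the digits printed from compound 2 to compound 3 (within the scatter), so this position does not separate these two five-membered aromatic rings with 1 hetero atom, one carrying sulfur and the other oxygen. The 1,3-thiazol-5-yl ring now stands apart from two neighbouring ring choices instead of one: the change to furan-2-yl gives a 2.9-fold higher number from compound 1 to compound 3 (0.46 log units; beyond the scatter), matching a 2.9-fold higher number from compound 1 to compound 2 (0.46 log units; beyond the scatter), which leaves compound 1 as the most potent of the three on this read-out. Nothing on hand offers an explanation for this pattern.

The three compounds show only that the 1,3-thiazol-5-yl ring differs from these two rings, and they cannot tell whether that difference comes from the ring as a whole or from a particular atom within it. Going by these compounds, how far the number moves with a phenyl ring, a pyridine ring or a simple open alkyl chain on the carbonyl carbon remains open, as does whether any such group would bring the number below that of compound 1.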